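A few compounds are considered here, and "the series" means these few. Any claim that something is new, unique, unknown or untested is made for them only; others in the source may bear on it.

Compound 3 `Cc1ccc(C(=O)n2c(-c3cn(-c4ccccc4)nc3-c3ccc(F)cc3)nc3ccccc32)cn1` is one of three measured analogues sharing a core; in an ADME assay on HEK-293T cells (Homo sapiens) for cytotoxicity, read by MTT assay, with a stated time of 24 h (on this read-out lower numbers stand for higher toxicity in this test and higher numbers for lower toxicity in this test), compound 3 gives 137000 nM, the second highest of the three numbers. Its nearest neighbour is compound 1 `Cc1cncc(C(=O)n2c(-c3cn(-c4ccccc4)nc3-c3ccc(F)cc3)nc3ccccc32)c1`, which in this assay gives 119000 nM; furthest lies compound 2 `Cc1ccc(-c2nn(-c3ccccc3)cc2-c2nc3ccccc3n2C(=O)c2ccccc2)cc1`, which gives 204000 nM, and both gaps sit within the scatter. Compound 4 `O=C(c1ccccc1)n1c(-c2cn(-c3ccccc3)nc2-c2ccc(F)cc2)nc2ccccc21` differs from compound 3 by phenyl in place of 6-methylpyridin-3-yl on a carbonyl carbon. Among the compounds with values here, the one step that touches the same place, a 1.2-fold higher number from compound 1 to compound 3 (0.06 log units; within the scatter), stayed within the scatter. Compound 2, which carries a benzoyl, shows a number within the scatter of compound 3, though it also differs elsewhere. Compound 4 is therefore expected to change by no more than a 1.1-fold higher number from compound 3 to compound 4 (0.04 log units; within the scatter), with an estimate of 150000 nM ranging from 80000 nM to 280000 nM.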

Compound 4, half-maximal cytotoxic concentration: 180000 nM
Beside the measured number, compound 4's estimate is 1.2-fold (0.08 log units) below it; measured number inside the range.
By their numbers in this assay, from the lowest: compounds 1, 3, 4 and 2 (each within the scatter of the next).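

In this assay, phenyl on the carbonyl carbon stays within the scatter of both methylpyridinyl groups (a 1.3-fold higher number from compound 3 to compound 4 (0.12 log units; within the scatter) and a 1.5-fold higher number from compound 1 to compound 4 (0.18 log units; within the scatter)), so this swap of the acyl ring leaves the number unresolved from the two earlier groups. The same holds at a second place, where fluoro in place of methyl on an aromatic carbon gives a 1.1-fold lower number from compound 2 to compound 4 (0.05 log units; within the scatter) and compound 4 completes a direct comparison with compound 2. As far as these compounds go, whether an amine or a carboxylic acid on the benzoyl ring would move the number beyond the scatter stays open. Nothing available gives a cause for these steps.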